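The source may report more compounds than this note shows. Statements on the series, on what has been measured and on what is new or still open speak of the compounds shown alone.

Of the compounds shown here, three have been measured in an assay on HEK293 cells for antagonist activity at transient receptor potential cation channel subfamily V member 3 (Homo sapiens), read by FLIPR and calcium flux; on this read-out lower numbers stand for stronger inhibition and higher numbers for weaker inhibition. Compound 1 `CC(O)(c1ccccn1)C1(c2ccc(Cl)c(Cl)c2)CCC1` gives 3400 nM in this assay. Compound 2 `O[C@H](c1ccccn1)[C@]1(c2ccc(Cl)c(Cl)c2)CCCO1` gives 470 nM in this assay. Compound 3 `C[C@]1(O)C[C@](c2cccc(OC(F)(F)F)c2)([C@H](O)c2ccccn2)C1` gives 1310 nM in this assay. On these numbers compound 3 stands second highest of the three: it sits between compound 1 above it and compound 2 below it, and both of those gaps are wider than the usual scatter of repeated runs.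

The next step leads from compound 3 to compound 4 `O[C@H](c1ccccn1)[C@]1(c2cccc(OC(F)(F)F)c2)C[C@H](O)C1`, which has not yet been measured in this assay. The change is hydrogen in place of methyl on a saturated ring carbon, a hydrogen in place of a methyl on a saturated ring carbon. Among the compounds with values here, no pair of measured compounds shows this change on its own, so there is no measured step to lean on. A single carbon removed from a ring position of this kind is a small edit, and the expectation is a step from compound 3 to compound 4 of a 1.1-fold lower number from compound 3 to compound 4 (0.04 log units; within the scatter) in this assay, which is no larger than the scatter.

Compound 4 is therefore estimated to give about 1200 nM in this assay, with a likely range from 450 nM to 3200 nM.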

Compound 4, antagonist equilibrium constant: 40 nM
The estimate for compound 4 lay 30-fold (1.48 log units) above the measured number, outside the stated range (below it).
By their numbers in this assay, from the lowest: compound 4; then compound 2; then compound 3; then compound 1.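

In this assay the exchange of a methyl for a hydrogen on a saturated ring carbon of a four-membered non-aromatic ring of carbon only gives a 33-fold lower number from compound 3 to compound 4 (1.52 log units; beyond the scatter) and so is a large change, well beyond the scatter. The earlier compounds shown here differ from one another in more than one place and could not isolate this position, whereas this pair shows that a methyl on this carbon, two ring bonds from the ring atom that bears a hydroxy(pyridin-2-yl)methyl group, weighs heavily on the read-out, even though the count of hydrogen-bond donors, acceptors and net charge carried by the exchanged groups is zero on both sides. Nothing measured here explains why so small an edit has so large a result.

As far as these compounds go, only hydrogen and methyl are seen at this carbon, so it remains open how an ethyl group, a fluorine atom or an amine there would compare with compound 4. From the compounds shown here alone, it is also open whether the same exchange would give a step of this size with the chlorine-bearing aromatic group found in compound 1 and compound 2.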